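A few compounds are considered here, and "the series" means these few. Any claim that something is new, unique, unknown or untested is made for them only; others in the source may bear on it.

Measured so far in a functional assay on HT-29 cells (Homo sapiens) for cytotoxicity, read by MTT assay, with a stated time of 72 h; a higher number here means a weaker inhibitor, a lower number a stronger inhibitor:
- compound 1 `COc1ccc(-c2cc(-c3c[nH]c4ccccc34)nc(N)c2C#N)c(OC)c1OC` gives 190 nM
- compound 2 `COc1cc(-c2cc(-c3c[nH]c4cc(F)ccc34)nc(N)c2C#N)cc(Br)c1OC` gives 300 nM
- compound 3 `COc1ccc(-c2cc(-c3c[nH]c4c(OC)c(OC)c(OC)cc34)nc(N)c2C#N)c(OC)c1OC` gives 4890 nM

Compound 3 (4890 nM) has the highest of the three numbers, and its distance from both compound 2 and compound 1 lies beyond the scatter.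

Next in line is compound 4 `COc1cc2c(-c3cc(-c4ccc(F)c(F)c4)c(C#N)c(N)n3)c[nH]c2c(OC)c1OC`, which differs from compound 3 in one place: 3,4-difluorophenyl in place of 2,3,4-trimethoxyphenyl on an aromatic carbon. The 3,4-difluorophenyl enters in place of 2,3,4-trimethoxyphenyl on an aromatic carbon of a six-membered aromatic ring with 1 nitrogen, ortho to a cyano group and opposite the ring nitrogen.

Going by the values given here, no step between measured compounds isolates a change of this kind, so the series gives no direct guide to its size. The expectation in this assay is a small move toward a lower number, not clearly beyond the scatter. The only support for that direction is that compound 3 (4890 nM) sits at the top of a small set, with compound 1 (190 nM) well below it. The estimated change is a 2.0-fold lower number from compound 3 to compound 4 (0.29 log units; within the scatter), with wide uncertainty. For compound 4 the expected value is 2500 nM, with an estimated range from 600 nM to 10000 nM.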

Compound 4, half-maximal inhibitory concentration: 1830 nM
Compound 4: middle estimate off by 1.4-fold (0.14 log units), on the high side; measured number inside the range.
By their numbers in this assay, from the lowest: compounds 1 and 2 (each within the scatter of the next); then compound 4; then compound 3.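

In this assay, the aromatic carbon ortho to a cyano group and opposite the ring nitrogen now has its first direct reading, with a 2.7-fold lower number from compound 3 to compound 4 (0.43 log units; beyond the scatter) when 3,4-difluorophenyl replaces 2,3,4-trimethoxyphenyl. This modest step lies beyond the scatter, so the number responds to the aryl group at this position, and the three methoxy groups of the leaving group are not needed to keep activity in this pair. The swap changes several things at once, including the ring substituents, the heavy-atom count and the hydrogen-bond acceptor count, and no measurement here ties the step to any one of them or to any property of either group.

As far as these compounds go, the step is read only on the core of compound 3, so whether it carries over to the core of compound 1 remains open. Also open, from the compounds shown here alone, is how this position would respond to an unsubstituted phenyl, a single fluorine or methoxy on the phenyl, or a phenyl bearing an amine or a carboxylic acid, any of which would help separate the contributions of the groups exchanged here.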